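Halogenated Aryl Exchange on a Shared Core

A few compounds are considered here, and "the series" means these few. Any claim that something is new, unique, unknown or untested is made for them only; others in the source may bear on it.

The three measured compounds share one core and differ only in the aromatic group carried on an amide-type nitrogen. Compound 1 `O=C(Nc1cccc(CNc2nccnc2Cl)c1)Nc1cccc2ccccc12` sits at a limit of the assay rather than at a number: in a functional assay on HepG2 cells (Homo sapiens) for antiproliferative activity, read by MTT assay, with a stated time of 48 h (a higher number here means a weaker inhibitor, a lower number a stronger inhibitor), compound 1 gives > 40000 nM (the limit of > 40000 nM in this assay, at which 1 of the 3 values shown sits). Compound 2 `O=C(Nc1cccc(CNc2nccnc2Cl)c1)Nc1ccccc1F` gives 10500 nM in this assay, and compound 3 `O=C(Nc1ccc(Cl)cc1)Nc1cccc(CNc2nccnc2Cl)c1` gives 8350 nM. Of the two numbers shown, compound 2 stands highest, with compound 3 nearest to it, the step being a 1.3-fold lower number from compound 2 to compound 3 (0.10 log units; within the scatter).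

Compound 4 `O=C(Nc1cccc(CNc2nccnc2Cl)c1)Nc1ccc(F)c(Cl)c1` has not yet been measured in this assay. It differs from compound 2 as follows: 3-chloro-4-fluorophenyl in place of 2-fluorophenyl on an amide-type nitrogen. Among the measured compounds shown here, the one measured step that bears on this change is a 1.3-fold lower number from compound 2 to compound 3 (0.10 log units; within the scatter), in which the same 2-fluorophenyl group left and a 4-chlorophenyl group entered at the same amide-type nitrogen, and that step stayed within the scatter. As compound 4 again introduces a chlorine-bearing phenyl group, only one that also retains a fluorine, the expected step is likewise small, namely a 1.4-fold lower number from compound 2 to compound 4 (0.15 log units; within the scatter), with no movement beyond the scatter anticipated. Compound 4 is therefore estimated at 7500 nM in this assay, with an expected range from 3000 nM to 20000 nM.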

Compound 4, half-maximal inhibitory concentration: 6750 nM
Compound 4: middle estimate off by 1.1-fold (0.05 log units), on the high side, within the range that was stated.
By their numbers in this assay, from the lowest: compounds 4, 3 and 2 (each within the scatter of the next). At a limit, above all of these: compound 1.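

In this assay, among the compounds shown here, carrying both a chlorine and a fluorine on the one phenyl group changes little, the record showing a 1.6-fold lower number from compound 2 to compound 4 (0.19 log units; within the scatter) and a 1.2-fold lower number from compound 3 to compound 4 (0.09 log units; within the scatter). The 3-chloro-4-fluorophenyl group thus joins 2-fluorophenyl and 4-chlorophenyl as a third halogenated phenyl group on the amide-type nitrogen that cannot be told apart from the others, so that across compound 2, compound 3 and compound 4 a second halogen on this ring brings no movement beyond the scatter. No measurement shown gives a reason for this sameness.

For the compounds shown here, compound 1, the only compound here with no halogen on this group, remains a limit of the assay and not a number: the limit of > 40000 nM in this assay, at which 1 of the 4 values shown sits. Still open, going by these compounds, is whether an amine, a carboxylic acid or a methoxy group on this phenyl ring, or a cyclohexyl group in its place, would move the number beyond the scatter, and whether anything on the shared core would do so where the aryl exchange has not.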